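Replacing Two Chlorines with a Methoxy Group on the Aryl Ring

A few compounds are considered here, and "the series" means these few. Any claim that something is new, unique, unknown or untested is made for them only; others in the source may bear on it.

Measured so far in an assay on HEK293 cells for activation of Kir3.1/Kir3.2 (Homo sapiens), read by thallium flux; a higher number here means that more compound is needed for the effect, a lower number that less compound is needed:
- compound 1, `Cc1cc(NC(=O)Cn2nnc(-c3ccccc3)n2)n(C2CCCC2)n1`: 163 nM
- compound 2, `Cc1cc(NC(=O)Cn2nnc(-c3cc(Cl)cc(Cl)c3)n2)n(C2CCCCC2)n1`: 980 nM

Of these two, compound 2 stands at the higher number, so more of it is needed than of compound 1, whose value is 163 nM; the gap between them lies beyond the usual scatter. For the measured compounds named here, the two compounds differ in more than one place, so no single structural step connects them, and only the two values themselves can be compared.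

Compound 3, `COc1cccc(-c2nnn(CC(=O)Nc3cc(C)nn3C3CCCCC3)n2)c1`, differs from compound 2 in one place: 3-methoxyphenyl in place of 3,5-dichlorophenyl on an aromatic carbon. The group that leaves and the group that enters have the same number of heavy atoms; the entering group brings one hydrogen-bond acceptor where the leaving group had none.

Going by the values given here, no measured step covers this change, so the expectation rests mainly on the value of compound 2, 980 nM. For compound 3 the estimate in this assay is 700 nM, within 200 nM to 2500 nM. The step expected from compound 2 to compound 3 is a 1.4-fold lower number from compound 2 to compound 3 (0.15 log units; within the scatter), a small move toward a lower number that may not exceed the scatter.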

Compound 3, half-maximal effective concentration: 117 nM
Beside the measured number, compound 3's estimate is 6.0-fold (0.78 log units) above it, and the stated range ends above it.
By their numbers in this assay, from the lowest: compounds 3 and 1 (each within the scatter of the next); then compound 2.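

In this assay, for the compounds shown here, exchanging 3,5-dichlorophenyl for 3-methoxyphenyl on the aromatic carbon of the five-membered ring gives an 8.4-fold lower number from compound 2 to compound 3 (0.92 log units; beyond the scatter) and is the first single-place step available here. The earlier pair differed in more than one place, so it could not tie a change in value to this position. This step shows that the value responds to what the aromatic ring at this position carries, even though both groups have the same number of heavy atoms. No supporting data bear on why the value moves.

Going by these compounds, the step removes two chlorines and adds one methoxy group at once, so the contribution of each remains open. A 3-chlorophenyl group at this position would help to separate them, while a 3-ethoxyphenyl group would test a longer chain on the oxygen.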